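The compounds below may be only part of what the source reports. "The series", "measured", "known", "first", "only" and "open" are said of these compounds alone.

Compound 1 `COc1ccccc1C(=O)Nc1ccc(Sc2nc3ccccc3s2)c(Cl)c1` and compound 2 `O=C(Nc1ccc(Sc2nc3ccccc3s2)c(Cl)c1)c1ccccc1O` share one core and differ only on the oxygen of the benzamide ring. In an assay for inhibition of HSP60/HSP10 (Homo sapiens), with a stated time of 60 min (a higher number here means a weaker inhibitor, a lower number a stronger inhibitor), compound 1 gives > 100000 nM, which is a limit of the assay and not a number. In this assay compound 2 gives > 100000 nM, likewise a limit and not a number. The change of hydrogen in place of methyl on an oxygen on an aromatic ring, a step that the two limits leave unreadable from compound 1 to compound 2, therefore cannot be read in either direction. Where compound 2 stands is thus known only as a limit, and the one other value shown is the same limit, as summarised by the limit of > 100000 nM in this assay, at which 2 of the 2 values shown sit.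

Compound 3 `COc1ccc(Br)cc1C(=O)Nc1ccc(Sc2nc3ccccc3s2)c(Cl)c1` differs from compound 2 by 5-bromo-2-methoxyphenyl in place of 2-hydroxyphenyl on a carbonyl carbon. Within the data shown here, the only measured step that touches the same part of the molecule is the one from compound 1 to compound 2, and it is unreadable. Among the measured compounds shown here, no measured step therefore gives a size or direction for this assay. With both measured compounds sitting at the limit, compound 3 is expected to give a reading that also sits at the limit, and the expected step of a number no higher from compound 2 to compound 3 (the limit leaves the size open) is none beyond the scatter. The estimate for compound 3 in this assay is 100000 nM, with a range from 30000 nM to 300000 nM.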

Compound 3, half-maximal inhibitory concentration: > 100000 nM
Compound 3: a limit, no number; the forecaster's own chance of this, stated with the estimate: 80%; the middle value sits exactly at the limit.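

In this assay compound 3 gives > 100000 nM, a limit of the assay and not a number. No step among compound 1, compound 2 and compound 3 can be read: the limit of > 100000 nM in this assay, at which 3 of the 3 values shown sit.

The compounds shown leave open whether any group on the carbonyl carbon of the shared core gives a readable number in this assay.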